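Cytotoxicity of two amidine series after a methoxy-to-hydroxy change

The compounds below may be only part of what the source reports. "The series", "measured", "known", "first", "only" and "open" are said of these compounds alone.

Measured compounds:
Compound 1 `COc1ccc(C(=N)N)cc1-c1cc2cc(C(=N)N)ccc2o1`: 179000 nM
Compound 2 `N=C(N)c1ccc(O)c(-c2cc3cc(C(=N)N)ccc3o2)c1`: > 217000 nM
Compound 3 `COc1cc(C(=N)NC(C)C)ccc1-c1cc2ccc(C(=N)NC(C)C)cc2o1`: > 181000 nM

In an ADME assay on L6 cells (Rattus norvegicus) for cytotoxicity (a higher number here means a weaker inhibitor, a lower number a stronger inhibitor), compound 1 gives 179000 nM. For compound 2 this assay reports only a limit, > 217000 nM. The change between them, (hydrogen in place of methyl on an oxygen on an aromatic ring), gave an at least 1.2-fold higher number from compound 1 to compound 2 (0.08 log units; that floor lies within the scatter). For compound 3 this assay likewise reports only a limit, > 181000 nM; the difference between the core of compound 3 and the core of compound 1 is not broken down here. For the measured compounds named here, compound 4 `CC(C)NC(=N)c1ccc(-c2cc3ccc(C(=N)NC(C)C)cc3o2)c(O)c1` carries the same change as the one from compound 1 to compound 2, namely (hydrogen in place of methyl on an oxygen on an aromatic ring). Because that earlier change gave an at least 1.2-fold higher number from compound 1 to compound 2 (0.08 log units; that floor lies within the scatter), compound 4 is expected to show about a step that the limit leaves unreadable from compound 3 to compound 4. The estimate for compound 4 is 220000 nM, between 150000 nM and 450000 nM, most likely reported again as a limit.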

Compound 4, half-maximal inhibitory concentration: > 183000 nM
Compound 4 was reported as a limit; the forecaster's own chance of this, stated with the estimate: 85%; the middle value lies beyond the limit too.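

Compound 3 and compound 4 are each reported only as a limit, and the methoxy-to-hydroxy step between them cannot be read. The compounds shown leave open whether that change shifts the true value of this pair in this assay.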